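From Cyclopropyl to Isobutyl on the Aromatic Carbon

A few compounds are considered here, and "the series" means these few. Any claim that something is new, unique, unknown or untested is made for them only; others in the source may bear on it.

Of the compounds shown here, two have been measured in an assay on cells with Cystic fibrosis transmembrane conductance regulator variant F508del (Homo sapiens) as the target, read by voltage clamp, with a stated time of 24 h, in the presence of a further agent that is not named here; a lower number here means a smaller maximal response, a higher number a larger maximal response. Compound 1 `COc1ncc(C(F)(F)F)cc1CO[C@H]1[C@H](C(C)(C)C)[C@@H](C(=O)O)N(C(=O)[C@@H]2CCCCO2)[C@H]1c1ccccc1C(C)C` gives 570% in this assay. Compound 2 `COc1ncc(C(F)(F)F)cc1CO[C@H]1[C@H](C(C)(C)C)[C@@H](C(=O)O)N(C(=O)[C@@H]2CCCCO2)[C@H]1c1ccccc1C1CC1` gives 610% in this assay, the higher of the two numbers. For the measured compounds named here, the single measured step, a number 40 percentage points higher from compound 1 to compound 2 (beyond the scatter), is the only one that bears on the change considered here.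

Compound 3 `COc1ncc(C(F)(F)F)cc1CO[C@H]1[C@H](C(C)(C)C)[C@@H](C(=O)O)N(C(=O)[C@@H]2CCCCO2)[C@H]1c1ccccc1CC(C)C` has not been measured in this assay. It differs from compound 2 by isobutyl in place of cyclopropyl on an aromatic carbon. The step from compound 1 to compound 2 shows that exchanging the alkyl group on this aromatic carbon can shift the largest response reached by an amount beyond the scatter. The group that enters in compound 3, isobutyl, is like the isopropyl of compound 1 in having no ring, whereas the cyclopropyl that leaves has one. A return toward the number of compound 1 is therefore the expectation, although a single pair is a thin basis and the direction rests on that one step alone.

Compound 3 is expected to give about 570% in this assay, within 490% to 650%. The expected step is a number 40 percentage points lower from compound 2 to compound 3 (beyond the scatter), roughly the size of the measured step but in the opposite direction.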

Compound 3, largest response reached (Emax), in percent of the reference or control that the assay uses: 472%
Compound 3: the middle estimate sits 98 percentage points above what was measured; measured number below the stated range.
By their numbers in this assay, from the lowest: compound 3; then compound 1; then compound 2.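

In this assay, isobutyl does not behave like isopropyl on this aromatic carbon, even though neither has a ring: the change gives a number 98 percentage points lower from compound 1 to compound 3 (beyond the scatter), so the absence of a ring does not by itself fix the largest response reached. Exchanging cyclopropyl for isobutyl gives a number 138 percentage points lower from compound 2 to compound 3 (beyond the scatter), which places compound 3 lowest of the three, with its steps to both others beyond the scatter, and shows that the alkyl group at this place can move the response down as well as up. No measurement at hand accounts for these differences among the three alkyl groups.

The three compounds leave open where a cyclobutyl ring, a tert-butyl group or a straight propyl chain on this aromatic carbon would fall, and so whether the high number of compound 2 goes with its ring and the low number of compound 3 with its longer chain. They also leave open whether the same order would hold if the other groups on the shared core were exchanged.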